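Fluoro for Trifluoromethyl: What Compound 3 Might Show

This account rests on a few compounds, and the source may have more. Where it says the series, first, only, none or still open, it means among the compounds named here.

Measured so far in an assay on isolated protein for inhibition of alpha-ketoglutarate-dependent dioxygenase alkB homolog 3 (Homo sapiens), read by polymerase chain reaction, with a stated time of 1 h; a lower number here means a stronger inhibitor, a higher number a weaker inhibitor:
compound 1 `Cc1[nH]n(-c2nc3ccccc3[nH]2)c(=O)c1Cc1cccc(Cl)c1` gives 540 nM
compound 2 `Cc1[nH]n(-c2nc3ccccc3[nH]2)c(=O)c1Cc1ccc(C(F)(F)F)cc1` gives 550 nM

Compound 2 and compound 1 lie within the scatter of each other, so nothing separates their two numbers. Compound 3 `Cc1[nH]n(-c2nc3ccccc3[nH]2)c(=O)c1Cc1ccc(F)cc1` differs from compound 2 in one place: fluoro in place of trifluoromethyl on an aromatic carbon. Going by the values given here, no measured pair covers such a change, so the size of the step in this assay has no anchor; a small loss, possibly still within the scatter, is expected rather than a large shift. Compound 3 is therefore estimated at 800 nM, with a range of 300 nM to 2500 nM. That estimate means an expected step of a 1.5-fold higher number from compound 2 to compound 3 (0.16 log units; within the scatter).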

Compound 3, half-maximal inhibitory concentration: 600 nM
For compound 3 the middle estimate is 1.3-fold (0.12 log units) above the measured one, within the range that was stated.
By their numbers in this assay, from the lowest: compounds 1, 2 and 3 (each within the scatter of the next).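

In this assay, the step from trifluoromethyl to fluoro on an aromatic carbon, para to a large group, is a 1.1-fold higher number from compound 2 to compound 3 (0.04 log units; within the scatter), so going from four heavy atoms to one at this place separates nothing. The change of 4-fluorophenyl in place of 3-chlorophenyl is a 1.1-fold higher number from compound 1 to compound 3 (0.05 log units; within the scatter), and it too separates nothing. On these data alone, whether an amine or a carboxylic acid on this aromatic carbon would give a number beyond the scatter stays open. No measurement offers a reason for these numbers.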